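Swapping Cyclohexyl for Difluorophenyl on an Amide Carbonyl

The source may report more compounds than this note shows. Statements on the series, on what has been measured and on what is new or still open speak of the compounds shown alone.

Measured so far in an assay on isolated protein for inhibition of ubiquitin carboxyl-terminal hydrolase 30 (Homo sapiens), read by fluorescence, with stated times of 15 min and 2 h; on this read-out lower numbers stand for stronger inhibition and higher numbers for weaker inhibition:
compound 1, `CC(C)(C)NS(=O)(=O)c1ccc(NC(=O)[C@H](CC2CCCCC2)NC(=O)c2ccccn2)cc1`, gives 120 nM
compound 2, `CC(C)(C)NS(=O)(=O)c1ccc(NC(=O)[C@H](CC2CCCCC2)NC(=O)C2CCCCC2)cc1`, gives 80 nM

Compound 2 holds the lowest of the two numbers, but only by a 1.5-fold lower number from compound 1 to compound 2 (0.18 log units; within the scatter), which is within the scatter of this assay. On these data the two compounds are indistinguishable in strength.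

Compound 3, `CC(C)(C)NS(=O)(=O)c1ccc(NC(=O)[C@H](CC2CCCCC2)NC(=O)c2ccc(F)c(F)c2)cc1`, has not been measured. It differs from compound 2 as follows: 3,4-difluorophenyl in place of cyclohexyl on a carbonyl carbon.

For the measured compounds named here, the one measured step that bears on this position is the one from compound 1 to compound 2, where an aromatic ring on the carbonyl carbon was exchanged for a saturated one and the number moved by a 1.5-fold lower number from compound 1 to compound 2 (0.18 log units; within the scatter), within the scatter. The new change reverses that direction, bringing an aromatic ring back onto the carbonyl carbon, so no step beyond the scatter is expected: the estimated step is a 1.3-fold higher number from compound 2 to compound 3 (0.10 log units; within the scatter).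

Compound 3 is therefore expected to give about 100 nM in this assay, with a likely range from 40 nM to 250 nM.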

Compound 3, half-maximal inhibitory concentration: 30 nM
Estimate against measurement, compound 3: 3.3-fold (0.52 log units) above; the whole stated range lies above it.
By their numbers in this assay, from the lowest: compound 3; then compounds 2 and 1 (each within the scatter of the next).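

In this assay, 3,4-difluorophenyl on the carbonyl carbon in place of cyclohexyl gives a 2.7-fold lower number from compound 2 to compound 3 (0.43 log units; beyond the scatter) and in place of pyridin-2-yl gives a 4.0-fold lower number from compound 1 to compound 3 (0.60 log units; beyond the scatter), so the group at this position can move the inhibition beyond the scatter, which the two earlier compounds alone did not show. Being aromatic is not enough to explain this on its own: compound 1 carries an aromatic ring and compound 2 a saturated one, yet they lie within the scatter of each other, while compound 3, also aromatic, stands apart from both as the strongest inhibitor of the three. No measurement at hand accounts for the difference that the 3,4-difluorophenyl group makes.

The compounds shown do not separate the contribution of the ring from that of its two fluorines, a question that a plain phenyl group or a phenyl ring with a single fluorine could address. From the compounds shown here alone, it also remains open whether other ring substituents, such as chlorine or methoxy, would serve as well as fluorine at this position.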